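Methoxy to Hydroxy on a Shared Growth-Inhibitor Core

The compounds below may be only part of what the source reports. "The series", "measured", "known", "first", "only" and "open" are said of these compounds alone.

Compound 1 `COc1cc(C)cc(-c2c(-c3ccnc(-c4ccc(N(C)C)cc4)c3)cnn2CC#N)c1`: 636 nM
Compound 2 `COc1cc(C)cc(-c2nn(CC#N)cc2-c2ccnc(-c3ccc(N(C)C)cc3)c2)c1`: 101 nM
Compound 3 `COc1cc(C)cc(-c2nn(CC#N)cc2-c2ccc(-c3cccc(C(C)=O)c3)nc2)c1`: 3280 nM

Of the compounds shown here, three have been measured in a functional assay on TK-10 cells (Homo sapiens) for inhibition, read by sulforhodamine B assay, with a stated time of 48 h; a higher number here means a weaker inhibitor of growth, a lower number a stronger inhibitor of growth. Compound 2 gives the lowest number, 101 nM, and is therefore the strongest growth inhibitor of the three: its nearest neighbour, compound 1, stands at 636 nM, a gap beyond the scatter, and compound 3, the furthest, stands at 3280 nM, a much wider gap that is also beyond the scatter. No two of the measured compounds differ in only one place, so none of these gaps can be tied to a single structural change.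

Compound 4 `Cc1cc(O)cc(-c2nn(CC#N)cc2-c2ccnc(-c3ccc(N(C)C)cc3)c2)c1` has not yet been measured. It keeps everything of compound 2 except one point: hydrogen in place of methyl on an oxygen on an aromatic ring The rest of the molecule, including the part carrying the dimethylamino group, is unchanged.

Nothing among the three measured compounds shows what this change does, so the expectation rests on the shared structure alone. A small step is expected, most likely within the scatter or slightly toward a higher number. On that basis compound 4 is estimated at 200 nM in this assay, within a range of 60 nM to 700 nM, which would mean an expected step of a 2.0-fold higher number from compound 2 to compound 4 (0.30 log units; within the scatter).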

Compound 4, concentration for 50% growth inhibition: 8400 nM
For compound 4 the middle estimate is 42-fold (1.62 log units) below the measured one; measured number above the stated range.
By their numbers in this assay, from the lowest: compound 2; then compound 1; then compound 3; then compound 4.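

In this assay, among these compounds, the exchange of methoxy for hydroxy, which turns 3-methoxy-5-methylphenyl into 3-hydroxy-5-methylphenyl, is the first change in this set that can be read on its own, and it gives an 83-fold higher number from compound 2 to compound 4 (1.92 log units; beyond the scatter) as a large step beyond the scatter. The methyl on this oxygen, a single carbon, therefore matters a great deal to growth inhibition in this pair, something the three earlier compounds, none of which differ in only one place, could not show, and the dimethylamino part and the rest of compound 2 alone do not keep the activity once that methyl is gone. No measurement at hand bears on why the step is so large.

As far as these compounds go, it remains open whether the oxygen needs this methyl in particular or any carbon group, which an ethoxy group, a longer chain on the oxygen or an amine in its place would help to separate. From the compounds shown here alone, it also remains open whether the same exchange would give a step of similar size on compound 1 or compound 3, which both still carry the methoxy group.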